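A few compounds are considered here, and "the series" means these few. Any claim that something is new, unique, unknown or untested is made for them only; others in the source may bear on it.

Going by the values given here, compound 1 `Cc1nc2c(N)ncnc2n1[C@@H]1O[C@H](CN(C)CCC(N)=O)[C@@H](O)[C@H]1O` is one of two compounds measured in an assay on isolated protein for inhibition of S-adenosylmethionine decarboxylase proenzyme (Homo sapiens) (on this read-out higher numbers stand for weaker inhibition and lower numbers for stronger inhibition), and in that assay compound 1 gives 400 nM. Its only measured neighbour is compound 2 `Cc1nc2c(N)ncnc2n1[C@@H]1O[C@H](C[S+](C)C)[C@@H](O)[C@H]1O`, which in this assay gives 3000 nM; the step of a 7.5-fold higher number from compound 1 to compound 2 (0.88 log units; beyond the scatter) exchanges the chain on the saturated chain carbon bound to a saturated ring carbon, so that compound 1 stands at the lowest of the two numbers shown.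

Compound 3 `CN(CCC(N)=O)C[C@H]1O[C@@H](n2cnc3c(N)ncnc32)[C@H](O)[C@@H]1O` differs from compound 1 in another place: hydrogen in place of methyl on an aromatic carbon, on an aromatic carbon of a five-membered aromatic ring with two nitrogen, part of a fused system of two rings. Among the compounds with values here, no measured step touches this position; the single step seen, from the chain exchange, offers no guide to the loss of this methyl, and the direction of the change is therefore open.

With the shared core otherwise unchanged, compound 3 is estimated to give 2000 nM in this assay, with a range of 500 nM to 8000 nM. This estimate means a step of a 5.0-fold higher number from compound 1 to compound 3 (0.70 log units; beyond the scatter), expected to weaken rather than strengthen inhibition, but with wide uncertainty.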

Compound 3, half-maximal inhibitory concentration: 7000 nM
For compound 3 the middle estimate is 3.5-fold (0.54 log units) below the measured one; the range from low to high includes it.
By their numbers in this assay, from the lowest: compound 1; then compound 2; then compound 3.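

The position on an aromatic carbon, between two ring nitrogen atoms, now proves to count in this assay: hydrogen in place of methyl there gives an 18-fold higher number from compound 1 to compound 3 (1.24 log units; beyond the scatter), a large step. Going by these compounds alone, this settles the direction for this pair, with the methyl-bearing compound 1 on the side of stronger inhibition, which the earlier compounds could not show because neither changed this position. The loss of this single methyl also moves the number further than the chain exchange does, a 7.5-fold higher number from compound 1 to compound 2 (0.88 log units; beyond the scatter), even though that exchange puts a group of 3 heavy atoms in place of a group of 7. No measurement at hand bears on the reason for the step at the methyl position.

The compounds shown carry only hydrogen and methyl at this position, so it remains open whether ethyl, a longer chain or an amine there would strengthen inhibition further or weaken it. On these data alone, it is also open whether losing the methyl would weigh the same alongside the sulfur-bearing group of compound 2 as it does alongside the chain of compound 1.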